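The source may report more compounds than this note shows. Statements on the series, on what has been measured and on what is new or still open speak of the compounds shown alone.

Measured compounds in a functional assay on HEK293 cells for antagonist activity at metabotropic glutamate receptor 5 (Homo sapiens), read by FLIPR and calcium flux; on this read-out higher numbers stand for weaker inhibition and lower numbers for stronger inhibition:
compound 1 `COc1ccc(C(=O)N[C@H]2CCC[C@H](NC(=O)c3cccc(Cl)c3)C2)cc1` gives 266 nM;
compound 2 `CN(C)c1cccc(C(=O)N[C@H]2CCC[C@H](NC(=O)c3cccc(Cl)c3)C2)c1` gives > 10000 nM, a limit of this assay, not a number;
compound 3 `O=C(N[C@H]1CCC[C@H](NC(=O)c2cnccn2)C1)c1cccc(Cl)c1` gives 1370 nM.

Compound 3 stands highest of the two numbers; the nearest is compound 1, with a 5.2-fold higher number from compound 1 to compound 3 (0.71 log units; beyond the scatter). Compound 2 sits at the limit of > 10000 nM in this assay, at which 1 of the 3 values shown sits, and the step from it is an at least 7.2-fold lower number from compound 2 to compound 3 (0.86 log units; beyond the scatter).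

Compound 4 `O=C(Cc1ccccn1)N[C@H]1CCC[C@H](NC(=O)c2cccc(Cl)c2)C1` differs from compound 3 in one place: (pyridin-2-yl)methyl in place of pyrazin-2-yl on a carbonyl carbon. Going by the values given here, no measured step inserts a methylene on the carbonyl carbon, and the only steps that bear on it are the exchanges of the aryl group on that same carbon, which moved this assay by modest to large amounts. A modest rise in this assay, to a weaker inhibition, is expected, roughly a 1.8-fold higher number from compound 3 to compound 4 (0.26 log units; within the scatter). For compound 4 the estimate in this assay is 2500 nM, with a range from 700 nM to 9000 nM.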

Compound 4, half-maximal inhibitory concentration: > 10000 nM
Compound 4 was reported as a limit (the forecaster's own chance of this, stated with the estimate: 20%); at least 4.0-fold (0.60 log units) between middle value and limit.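

In this assay, (pyridin-2-yl)methyl on this carbonyl carbon costs far more than pyrazin-2-yl or 4-methoxyphenyl, with an at least 7.2-fold higher number from compound 3 to compound 4 (0.86 log units; beyond the scatter) and an at least 37-fold higher number from compound 1 to compound 4 (1.57 log units; beyond the scatter). The value of compound 4 is a limit, not a number, so these steps give only a minimum size. The step from compound 2 to compound 4 cannot be read, since both values are limits: the limit of > 10000 nM in this assay, at which 2 of the 4 values shown sit.

Going by these compounds, whether the loss belongs to the inserted methylene or to the pyridin-2-yl ring stays open. Benzyl or directly attached pyridin-2-yl on this carbonyl carbon would separate the two.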